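Thiophene Isomer Swap in a Dihydropyrimidinone Adenosine Ligand Series

The source may hold more compounds than are shown below. What is called first, only, known or untested is meant among the compounds shown, and "the series" means these compounds.

Measured compounds:
compound 1, `CC1=C(C(=O)CC(C)C)C(c2ccoc2)NC(=O)N1`, 23%;
compound 2, `CC1=C(C(=O)CC(C)C)C(c2cccs2)NC(=O)N1`, 19%.

In an assay on membranes from CHO cells for displacement of a labelled ligand from adenosine receptor A1 (Homo sapiens), read by scintillation counting, with a stated time of 60 min, tested at 1 uM (a higher number here means more inhibition at the concentration tested (going by the name of the read-out), a lower number less inhibition), compound 2 gives 19%, the lower of the two numbers, with its nearest neighbour compound 1 at 23%, a gap within the scatter. Compound 3, `CC1=C(C(=O)CC(C)C)C(c2ccsc2)NC(=O)N1`, differs from compound 2 by thiophen-3-yl in place of thiophen-2-yl on a saturated ring carbon. Within the data shown here, the only measured step, a number 4 percentage points lower from compound 1 to compound 2 (within the scatter), changes the same saturated ring carbon and stays within the scatter, so no step beyond the scatter is expected here, a number 2 percentage points higher from compound 2 to compound 3 (within the scatter). Compound 3 is therefore estimated at 21%, in the range 8% to 34%.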

Compound 3, a percentage reported as inhibition, at one concentration (the size of the read-out at that concentration, not a potency): 37%
Compound 3: the middle estimate sits 16 percentage points below what was measured; the measured number lies above the stated range.
By their numbers in this assay, from the lowest: compounds 2 and 1 (each within the scatter of the next); then compound 3.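

In this assay the saturated ring carbon responds to how the thiophene is attached, not only to which ring it carries: thiophen-3-yl in place of thiophen-2-yl gives a number 18 percentage points higher from compound 2 to compound 3 (beyond the scatter) with the same atoms in both groups. Thiophen-3-yl in place of furan-3-yl gives a number 14 percentage points higher from compound 1 to compound 3 (beyond the scatter) and so also separates from the furan, which thiophen-2-yl did not. Nothing available explains this difference. From the compounds shown here alone, whether phenyl or pyridin-3-yl at this carbon would raise the number further remains open. So does whether a longer chain in place of the isobutylcarbonyl group would preserve the gap between the thiophene isomers.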